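The source may report more compounds than this note shows. Statements on the series, on what has been measured and on what is new or still open speak of the compounds shown alone.

Working notes on the series sharing one core. In an assay on isolated protein (Cavia porcellus) with Sigma non-opioid intracellular receptor 1 (Homo sapiens) as the target, read by radioligand binding (on this read-out higher numbers stand for weaker inhibition and lower numbers for stronger inhibition), compound 1 `CN(C)CCCCOc1ccc2oc(-c3ccccc3)cc(=O)c2c1` gives 720 nM, compound 2 `O=c1cc(-c2ccccc2)oc2ccc(OCCCCCCN3CCCC(O)C3)cc12` gives 86 nM, and compound 3 `O=c1cc(-c2ccccc2)oc2ccc(OCCCCCCN3CCNCC3c3ncccn3)cc12` gives 1630 nM. Compound 3 thus stands highest of the three numbers, nearest to compound 1 and furthest from compound 2. Compound 4 `NCCCCCCOc1ccc2oc(-c3ccccc3)cc(=O)c2c1` differs from compound 3 by amino in place of 2-(pyrimidin-2-yl)piperazin-1-yl on a saturated chain carbon, six bonds along the chain from an oxygen on an aromatic ring. For the measured compounds named here, two measured steps bear on the group on the saturated chain carbon: an 8.4-fold lower number from compound 1 to compound 2 (0.92 log units; beyond the scatter) and a 19-fold higher number from compound 2 to compound 3 (1.28 log units; beyond the scatter), both beyond the scatter, with 2-(pyrimidin-2-yl)piperazin-1-yl in compound 3 giving the highest number. Replacing it by amino is therefore expected to lower the number in this assay, by a step of the order of a 3.3-fold lower number from compound 3 to compound 4 (0.51 log units; beyond the scatter), without reaching compound 2. Compound 4 is estimated at 500 nM, within a range from 150 nM to 2000 nM.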

Compound 4, half-maximal inhibitory concentration: 2100 nM
Compound 4: middle estimate off by 4.2-fold (0.62 log units), on the low side, and the stated range ends below it.
By their numbers in this assay, from the lowest: compound 2; then compound 1; then compounds 3 and 4 (each within the scatter of the next).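

In this assay, amino and 2-(pyrimidin-2-yl)piperazin-1-yl read alike on the saturated chain carbon (a 1.3-fold higher number from compound 3 to compound 4 (0.11 log units; within the scatter)), so the larger group with its two rings shows no measurable difference from amino. The low number of compound 2 therefore goes with 3-hydroxypiperidin-1-yl, not with the chain alone (a 24-fold higher number from compound 2 to compound 4 (1.39 log units; beyond the scatter)), and amino on the longer chain also falls short of compound 1 (a 2.9-fold higher number from compound 1 to compound 4 (0.46 log units; beyond the scatter)). No measured evidence explains these steps. The compounds shown leave open whether the hydroxyl matters, which plain piperidin-1-yl would test, and how dimethylamino reads six bonds along the chain from an oxygen on an aromatic ring.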